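Heteroaryl exchange next to the ring nitrogen, 3-hydroxyphenyl series

The compounds below may be only part of what the source reports. "The series", "measured", "known", "first", "only" and "open" are said of these compounds alone.

Measured so far:
compound 1 `Oc1cccc(-c2cc(-c3ccccc3)nc(-c3ccccc3)c2)c1`: 0%
compound 2 `Oc1cccc(-c2cc(-c3ccccc3)nc(-c3ccco3)c2)c1`: 3.5%
compound 3 `Oc1cccc(-c2cc(-c3ccccc3)nc(-c3ccccn3)c2)c1`: 2.8%

All three readings come from an assay on isolated protein for inhibition of DNA topoisomerase 1 (Homo sapiens), with a stated time of 30 min, tested at 20 uM; a higher number here means a stronger effect of the compound at the concentration tested, a lower number a weaker effect. Compound 3 stands second highest of the three numbers, nearest to compound 2 and furthest from compound 1, yet every step is small: a number 3.5 percentage points higher from compound 1 to compound 2 (within the scatter), a number 2.8 percentage points higher from compound 1 to compound 3 (within the scatter) and a number 0.7 percentage points lower from compound 2 to compound 3 (within the scatter) all lie within the scatter. Compound 4 `Oc1cccc(-c2cc(-c3ccccc3)nc(-c3ccncc3)c2)c1` differs from compound 3 by pyridin-4-yl in place of pyridin-2-yl on an aromatic carbon. For the measured compounds named here, no measured step swaps one pyridyl for another, but each exchange of the group on that aromatic carbon so far has left the reading essentially unchanged, so no step beyond the scatter is expected: a number 0.2 percentage points higher from compound 3 to compound 4 (within the scatter). Compound 4 is estimated at 3%, with a range from 0% to 12%.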

Compound 4, a percentage reported as inhibition, at one concentration (the size of the read-out at that concentration, not a potency): 0.9%
Compound 4: the middle estimate sits 2.1 percentage points above what was measured, and the stated range covers the measured number.
By their numbers in this assay, from the lowest: compounds 1, 4, 3 and 2 (each within the scatter of the next).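

Swapping one pyridyl isomer for the other, with the same atoms joined differently, gives a number 1.9 percentage points lower from compound 3 to compound 4 (within the scatter), so the place of the nitrogen within this group does not separate the two compounds. The other comparisons, a number 2.6 percentage points lower from compound 2 to compound 4 (within the scatter) and a number 0.9 percentage points higher from compound 1 to compound 4 (within the scatter), add pyridin-4-yl to the phenyl, furan-2-yl and pyridin-2-yl groups that cannot be told apart at this aromatic carbon. No evidence here bears on this result.

Still open, on these data alone, is whether any group on this carbon can move the reading beyond the scatter. An aminomethyl group or a carboxylic acid there would test this.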